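The compounds below may be only part of what the source reports. "The series", "measured", "known", "first", "only" and "open" are said of these compounds alone.

Compound 1 `N#Cc1ccc(CNc2nc(-c3ccccc3C(F)(F)F)nc3ccccc23)cc1`: 5700 nM
Compound 2 `FC(F)(F)c1ccccc1-c1nc(NCc2ccc(-c3cccc(Cl)c3)cc2)c2ccccc2n1`: 2700 nM

Within the data shown here, in an assay on a protein complex for inhibition of ubiquitin carboxyl-terminal hydrolase 1/WD repeat-containing protein 48 (Homo sapiens), read by fluorescence (on this read-out lower numbers stand for stronger inhibition and higher numbers for weaker inhibition), compound 2 holds the lower of the two numbers measured so far. Among the measured compounds shown here, the only measured step, a 2.1-fold lower number from compound 1 to compound 2 (0.32 log units; beyond the scatter), is modest. Compound 3 `FC(F)(F)c1ccccc1-c1nc(NCc2ccc(-c3ccc(Cl)c(Cl)c3)cc2)c2ccccc2n1` differs from compound 2 by chloro in place of hydrogen on an aromatic carbon. For the measured compounds named here, no measured step adds a chloro group, so that one step is only a loose guide, and a change no larger than the scatter seems most likely. Compound 3 is expected to give 2000 nM, between 700 nM and 6000 nM. The step this estimate implies, a 1.4-fold lower number from compound 2 to compound 3 (0.13 log units; within the scatter), is expected to stay within the scatter.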

Compound 3, half-maximal inhibitory concentration: 2200 nM
Compound 3: the middle estimate sits 1.1-fold (0.04 log units) below what was measured; measured number inside the range.
By their numbers in this assay, from the lowest: compounds 3 and 2 (each within the scatter of the next); then compound 1.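

Chloro in place of hydrogen, turning 3-chlorophenyl into 3,4-dichlorophenyl, gives a 1.2-fold lower number from compound 2 to compound 3 (0.09 log units; within the scatter) in this assay, so adding this atom at this place brings no real change. Putting 3,4-dichlorophenyl in place of cyano gives a 2.6-fold lower number from compound 1 to compound 3 (0.41 log units; beyond the scatter), so the modest edge over cyano remains. Nothing available explains these results. Still open, as far as these compounds go, is whether a different group at this place, such as an amine, a carboxylic acid or a longer chain, would shift the number beyond the scatter.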